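Restoring a Fluoro on the Triazole Aryl Group

The compounds below may be only part of what the source reports. "The series", "measured", "known", "first", "only" and "open" are said of these compounds alone.

Measured so far, all in a functional assay on DU-145 cells (Homo sapiens) for inhibition, read by MTT assay, with a stated time of 24 h; a lower number here means a stronger inhibitor, a higher number a weaker inhibitor:
- compound 1, `CCOC(=O)C1=Cc2ccccc2OC1(OCc1cn(-c2ccc(F)cc2)nn1)C(F)(F)F`, gives 8900 nM
- compound 2, `CCOC(=O)C1=Cc2ccccc2OC1(OCc1cn(CC(=O)Nc2ccccc2Br)nn1)C(F)(F)F`, reaches only the limit of the assay, > 150000 nM
- compound 3, `CCOC(=O)C1=Cc2ccccc2OC1(OCc1cn(-c2ccccc2)nn1)C(F)(F)F`, likewise reaches only the limit of the assay, > 150000 nM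

Compound 3 therefore has no exact number, only a limit, and it shares this with compound 2, since (the limit of > 150000 nM in this assay, at which 2 of the 3 values shown sit). Compound 4, `CCOC(=O)C1=Cc2ccccc2OC1(OCc1cn(-c2ccc(F)c([N+](=O)[O-])c2)nn1)C(F)(F)F`, has not yet been measured. It differs from compound 3 by 4-fluoro-3-nitrophenyl in place of phenyl on an aromatic nitrogen.

Going by the values given here, two measured steps touch this change. The step of an at least 16-fold higher number from compound 1 to compound 3 (1.22 log units; beyond the scatter) shows that taking away the fluoro on the aromatic carbon costs a large amount of potency. The step that the two limits leave unreadable from compound 2 to compound 3 cannot be read, as both ends are limits. Compound 4 brings the fluoro back and adds a nitro beside it, so a large step towards a lower number is expected, of about the size an at least 12-fold lower number from compound 3 to compound 4 (1.09 log units; beyond the scatter). Compound 4 is estimated at 12000 nM, within 2500 nM to 100000 nM.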

Compound 4, half-maximal inhibitory concentration: 13200 nM
For compound 4 the middle estimate is 1.1-fold (0.04 log units) below the measured one; the measured number falls inside the stated range.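

In this assay, 4-fluoro-3-nitrophenyl on the aromatic nitrogen gives an at least 11-fold lower number from compound 3 to compound 4 (1.05 log units; beyond the scatter), and the same group in place of ((2-bromophenyl)carbamoyl)methyl gives an at least 11-fold lower number from compound 2 to compound 4 (1.05 log units; beyond the scatter). Nitro in place of hydrogen on an aromatic carbon gives a 1.5-fold higher number from compound 1 to compound 4 (0.17 log units; within the scatter), so the fluoro-bearing ring keeps its potency with the nitro present, and the nitro has no readable effect on top of the fluoro. Both large steps are minimum sizes only, because each starts from a compound that sits at a limit: the limit of > 150000 nM in this assay, at which 2 of the 4 values shown sit.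

Among the compounds shown, no ring carries the nitro without the fluoro, so what the nitro does on its own stays open. From the compounds shown here alone, whether a chloro, an amine or a carboxylic acid in place of the fluoro would keep the potency also stays open.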